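Dihydroxyphenyl pyrazoles: does a chloro change growth inhibition?

The source may report more compounds than this note shows. Statements on the series, on what has been measured and on what is new or still open speak of the compounds shown alone.

This study measures how strongly small molecules stop cancer cells from growing, using a functional assay on cells (Cancer cell lines, Homo sapiens) for cytotoxicity, read by sulforhodamine B assay, with a stated time of 48 h; on this read-out higher numbers stand for weaker inhibition of growth and lower numbers for stronger inhibition of growth. Of the compounds shown here, three have been tested so far. Compound 1 `COc1ccc(OC)c(-c2cc(-c3ccccc3)nn2-c2ccc(S(N)(=O)=O)cc2)c1` gives 28800 nM in this assay. Compound 2 `COc1ccc(OC)c(-c2cc(-c3ccc(Cl)cc3)nn2-c2ccc(S(=O)(=O)NC(C)=O)cc2)c1` gives 21900 nM. Compound 3 `Oc1ccc(O)c(-c2cc(-c3ccccc3)nn2-c2ccccc2)c1`, which carries two hydroxy groups on its side ring, gives 100000 nM, the highest of the three numbers; compound 1 sits nearest to it and compound 2 furthest, both beyond the usual scatter, so compound 3 is the weakest inhibitor among the three.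

The next compound, compound 4 `Oc1ccc(O)c(-c2cc(-c3ccc(Cl)cc3)nn2-c2ccccc2)c1`, differs from compound 3 in one place: chloro in place of hydrogen on an aromatic carbon. Compounds 1 and 2 differ from each other in more than one place, so they cannot tell what this single change does on its own. For the measured compounds named here, no measured pair isolates it. The expectation is therefore a small step from compound 3 to compound 4, a 1.3-fold lower number from compound 3 to compound 4 (0.10 log units; within the scatter), not clearly beyond the scatter. Compound 4 is estimated at 80000 nM, within a range from 30000 nM to 200000 nM.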

Compound 4, concentration for total growth inhibition: 30700 nM
For compound 4 the middle estimate is 2.6-fold (0.42 log units) above the measured one; measured number inside the range.
By their numbers in this assay, from the lowest: compounds 2, 1 and 4 (each within the scatter of the next); then compound 3.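

In this assay the change from phenyl to 4-chlorophenyl, with the two hydroxy groups kept in place, gives a 3.3-fold lower number from compound 3 to compound 4 (0.51 log units; beyond the scatter) and so moves the result towards stronger inhibition of growth. For the compounds shown here, this is the first reading of this change on its own, as compound 1 and compound 2 differ in more than one place and could not isolate it. It shows that one chloro on this aromatic carbon, para to a large group, is enough to shift the number beyond the usual scatter, but nothing available explains the shift.

Going by these compounds, it remains open whether a fluoro, a methyl, an amine or a carboxylic acid at this same place would give a similar step. On these data alone, it is also open whether the chloro would have the same effect on a compound with methoxy groups and a sulfonamide, such as compound 1.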